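Ethyl Ester of Compound 3: Expected Growth Inhibition

This account rests on a few compounds, and the source may have more. Where it says the series, first, only, none or still open, it means among the compounds named here.

Compound 1, `O=C(O)CCc1ccncc1-c1ccc2ccccc2c1`: > 30000 nM
Compound 2, `O=C(O)[C@@H]1CCCN1C(=O)/C=C/c1ccncc1-c1ccc2ccccc2c1`: "not determined" (no result reported)
Compound 3, `O=C(O)/C=C/c1ccncc1-c1ccc2ccccc2c1`: > 30000 nM

In a functional assay on HCT-116 cells (Homo sapiens) for inhibition, read by MTT assay, with a stated time of 72 h (a lower number here means a stronger inhibitor of growth, a higher number a weaker inhibitor of growth), compound 3 gives > 30000 nM, which is a limit of the assay and not a number. Compound 1 likewise gives > 30000 nM, again a limit. For compound 2 the result is "not determined" (no result reported), so nothing can be drawn from it. Among the compounds with values here, the one single-change step among the measured compounds, a step that the two limits leave unreadable from compound 1 to compound 3, cannot be sized because both of its ends sit at the limit of > 30000 nM in this assay, at which 2 of the 3 values shown sit. Compound 4, `CCOC(=O)/C=C/c1ccncc1-c1ccc2ccccc2c1`, differs from compound 3 by ethyl in place of hydrogen on an oxygen next to a carbonyl group, that is, carboxy becomes ethoxycarbonyl. Within the data shown here, no measured step touches a change of this kind, and compound 3 itself stands only at a limit, so the numbers give no direction for the change. For compound 4 a step of an at least 1.5-fold lower number from compound 3 to compound 4 (0.17 log units; that floor lies within the scatter) in this assay is therefore expected, resting on little more than the limit of compound 3. Compound 4 is estimated at 20000 nM, between 5000 nM and 60000 nM, with a fair chance that again only a limit is reported.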

Compound 4, concentration for 50% growth inhibition: 910 nM
For compound 4 the middle estimate is 22-fold (1.34 log units) above the measured one, outside the stated range (below it).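

Turning carboxy into ethoxycarbonyl gives, in this assay, an at least 32-fold lower number from compound 3 to compound 4 (1.51 log units; beyond the scatter), and compound 4 thereby has the first real number in this series rather than a limit. Replacing 2-carboxyethyl with 2-(ethoxycarbonyl)ethenyl gives an at least 32-fold lower number from compound 1 to compound 4 (1.51 log units; beyond the scatter), a comparison that changes the chain as well as the acid. Both steps are floors and not exact sizes, since compound 1 and compound 3 each stand only at a limit of the assay: the limit of > 30000 nM in this assay, at which 2 of the 4 values shown sit.

On these data alone, whether ethyl itself matters remains open, and a methyl ester, a longer butyl ester or an amide in this place would show how much the group on the carbonyl can vary. A 2-(ethoxycarbonyl)ethyl group would show whether the ester still gives a measurable value without the double bond of the ethenyl chain.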